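This account rests on a few compounds, and the source may have more. Where it says the series, first, only, none or still open, it means among the compounds named here.

Going by the values given here, in an ADME assay on HeLa cells (Homo sapiens) for cytotoxicity, read by MTT assay, with a stated time of 2 days (on this read-out lower numbers stand for higher toxicity in this test and higher numbers for lower toxicity in this test), compound 1 `CCOC(=O)c1sc2cc(Oc3ccnc(C(=O)NC)c3)ccc2c1CC` gives 16700 nM, while compound 2 `CCOC(=O)c1sc2cc(Oc3ccnc(C(=O)NC)c3)ccc2c1N` gives 450 nM, the lower of the two numbers so far. Compound 3 `CCOC(=O)c1sc2cc(Oc3ccnc(C(=O)NC)c3)ccc2c1C#N` has cyano in place of amino on an aromatic carbon. Among the compounds with values here, only one measured step bears on this place on the shared core: a 37-fold lower number from compound 1 to compound 2 (1.57 log units; beyond the scatter), a large change beyond the scatter, seen when amino replaced ethyl. Since compound 3 also loses that amino, a sizeable rise is expected, though one measured step is thin evidence. The expected change is an 11-fold higher number from compound 2 to compound 3 (1.05 log units; beyond the scatter). For compound 3, the estimated value is 5000 nM, within a range of 900 nM to 28000 nM.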

Compound 3, half-maximal cytotoxic concentration: > 100000 nM
Compound 3: only a limit was reported (the forecaster's own chance of this, stated with the estimate: 10%); at least 20-fold (1.30 log units) between middle value and limit.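

Compound 3 gives only a limit, not a number, in this assay: the limit of > 100000 nM in this assay, at which 1 of the 3 values shown sits. With cyano at this position, the number moves far from amino, by an at least 220-fold higher number from compound 2 to compound 3 (2.34 log units; beyond the scatter), and also away from ethyl, by an at least 5.9-fold higher number from compound 1 to compound 3 (0.77 log units; beyond the scatter). Ethyl therefore no longer marks the high end: of the three groups, only amino gives a low number, and the two steps show that this position can shift the number in both directions from ethyl.

Going by these compounds, how far compound 3 really lies beyond its limit stays open. So does where a hydroxyl group, a methylamino group or a carboxylic acid at this position would fall.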